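Extending the methyl on the 1,2-oxazol-5-yl group

The source may report more compounds than this note shows. Statements on the series, on what has been measured and on what is new or still open speak of the compounds shown alone.

Measured so far:
compound 1 `CC(=O)OC[C@H]1O[C@@H](n2cc(-c3cn(Cc4ccccc4)nn3)c(=O)[nH]c2=O)C[C@@H]1OC(C)=O` gives 98.2%
compound 2 `CC(=O)OC[C@H]1O[C@@H](n2cc(-c3cn(Cc4ccc(C(C)(C)C)cc4)nn3)c(=O)[nH]c2=O)C[C@@H]1OC(C)=O` gives 106%
compound 3 `CC(=O)OC[C@H]1O[C@@H](n2cc(-c3cc(C)no3)c(=O)[nH]c2=O)C[C@@H]1OC(C)=O` gives 101%

All three numbers come from a functional assay on NCI-H23 cells (Homo sapiens) for cytotoxicity, read by sulforhodamine B assay, tested at 10 uM; a higher number here means more inhibition at the concentration tested (going by the name of the read-out), a lower number less inhibition. Compound 3 stands second highest of the three; its nearest neighbour is compound 1, a number slightly lower and within the scatter, and the furthest is compound 2, a number slightly higher and still within the scatter. The three values therefore sit together, with no order to be read among them.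

Compound 4 `CCCCCc1cc(-c2cn([C@H]3C[C@H](OC(C)=O)[C@@H](COC(C)=O)O3)c(=O)[nH]c2=O)on1` is not yet measured. It differs from compound 3 in one place: butyl in place of hydrogen on a saturated chain carbon bound to an aromatic carbon.

For the measured compounds named here, one measured step bears on it. Between compound 1 and compound 2 a bulky alkyl group was added to an aromatic carbon, and a number 7.8 percentage points higher from compound 1 to compound 2 (within the scatter). Growing an alkyl group on the core gave no change beyond the scatter there. Going by the values given here, the change from compound 3 to compound 4 also grows an alkyl group, though on a saturated chain carbon bound to an aromatic carbon rather than on the ring itself, and with only one such step in hand the expectation is the same: no step beyond the scatter, so the step expected is a number 1 percentage points lower from compound 3 to compound 4 (within the scatter). Compound 4 is accordingly estimated at 100%, with a range from 88% to 110%.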

Compound 4, a percentage reported as inhibition, at one concentration (the size of the read-out at that concentration, not a potency): 88.9%
The estimate for compound 4 lay 11.1 percentage points above the measured number; low and high end bracket the measured number.
By their numbers in this assay, from the lowest: compounds 4, 1, 3 and 2 (each within the scatter of the next, the first and the last beyond it).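

In this assay, for the compounds shown here, taking the isoxazole substituent from 3-methyl-1,2-oxazol-5-yl to 3-pentyl-1,2-oxazol-5-yl gives a number 12.1 percentage points lower from compound 3 to compound 4 (beyond the scatter), the first single change to pass the scatter. Alkyl growth is therefore not neutral at this position on the saturated chain carbon bound to an aromatic carbon, whereas the only earlier alkyl step, tert-butyl on an aromatic carbon, gave a number 7.8 percentage points higher from compound 1 to compound 2 (within the scatter); the two steps differ in both the group added and the place, so they do not define a general rule for alkyl groups, and the fall is modest, with compound 4 still giving 88.9%. No measurement at hand gives a reason for this step.

From the compounds shown here alone, a single pentyl example does not establish a trend with chain length, so it remains open whether an ethyl or propyl group would sit with the methyl of compound 3 and whether an octyl chain would fall further. Going by these compounds, it also remains open whether a pentyl chain ending in an amine or a carboxylic acid would give the same reading, and a reading at one concentration does not settle potency.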